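This account rests on a few compounds, and the source may have more. Where it says the series, first, only, none or still open, it means among the compounds named here.

The measured compounds all share one core and differ only in the side arm attached to it. In a functional assay (aorta) with Rattus norvegicus as the target (on this read-out higher numbers stand for an effect only at larger amounts of compound and lower numbers for an effect already at smaller amounts), compound 1 `COc1ccc(-c2nc(CNC(=O)N3CCOCC3)sc2-c2ccc(OC)cc2)cc1` gives 12 uM, the highest of the two numbers shown. Compound 2 `COc1ccc(-c2nc(C(=O)N3CCCCC3CCO)sc2-c2ccc(OC)cc2)cc1` gives 6.8 uM in this assay, which lies within the scatter of compound 1, so the two cannot be told apart. Compound 3 `CCOC(=O)C1=C(C)N=C(C)/C(=C(/O)OCC)C1c1nc(-c2ccc(OC)cc2)c(-c2ccc(OC)cc2)s1` gives > 32 uM in this assay, a limit of the measurement and not a number, sitting at the limit of > 32 uM in this assay, at which 1 of the 3 values shown sits. The unmeasured compound 4 `COc1ccc(-c2nc(CCC(=O)O)sc2-c2ccc(OC)cc2)cc1` differs from compound 1 by one change (carboxymethyl in place of ((morpholin-4-yl)carbonyl)amino on a saturated chain carbon bound to an aromatic carbon). Among the measured compounds shown here, no measured pair shows a change of this kind, so for compound 4 an expected step of a 1.3-fold higher number from compound 1 to compound 4 (0.12 log units; within the scatter), towards a somewhat larger number or none beyond the scatter, is the best guess. Compound 4 is therefore estimated at 16 uM, between 5 uM and 40 uM.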

Compound 4, concentration for half-maximal effect: > 100 uM
Compound 4 gave a limit, no number (the forecaster's own chance of this, stated with the estimate: 30%); middle value at least 6.2-fold (0.79 log units) from the limit.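

In this assay compound 4 gives > 100 uM, a limit of the assay and not a number. Among the compounds shown here, putting carboxymethyl in place of ((morpholin-4-yl)carbonyl)amino on a saturated chain carbon bound to an aromatic carbon gives an at least 8.3-fold higher number from compound 1 to compound 4 (0.92 log units; beyond the scatter), the first single-place step here, and it shows that the group at this place matters. Its full size stays unknown because only a limit was reached: the limit of > 100 uM in this assay, at which 1 of the 4 values shown sits.

The compounds shown cannot separate the effect of the incoming carboxylic acid from that of losing the morpholine ring. A methyl ester or an amine at this place would help to tell these apart.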